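The source may hold more compounds than are shown below. What is called first, only, known or untested is meant among the compounds shown, and "the series" means these compounds.

Of the compounds shown here, three sharing one core have been measured in a functional assay on HCT-116 cells (Homo sapiens) for antiproliferative activity, read by MTT assay, with a stated time of 48 h; a higher number here means a weaker inhibitor, a lower number a stronger inhibitor. Compound 1 `O=C(Nc1cccc(/C=C/C(=O)c2nc3ccccc3[nH]2)c1)c1cccc(Cl)c1` gives 1120 nM, compound 2 `Cc1cccc(C(=O)Nc2cccc(/C=C/C(=O)c3nc4ccccc4[nH]3)c2)c1` gives 1420 nM, and compound 3 `O=C(/C=C/c1cccc(NS(=O)(=O)c2ccc(Cl)cc2)c1)c1nc2ccccc2[nH]1` gives 1960 nM. On the numbers shown compound 3 sits at the upper end, but the gaps to it are small: a 1.8-fold higher number from compound 1 to compound 3 (0.24 log units; within the scatter) and a 1.4-fold higher number from compound 2 to compound 3 (0.14 log units; within the scatter), neither of them beyond the scatter. Compound 4 `Cc1ccc(S(=O)(=O)Nc2cccc(/C=C/C(=O)c3nc4ccccc4[nH]3)c2)cc1C` is not yet measured; it differs from compound 3 in one place, (3,4-dimethylphenyl in place of 4-chlorophenyl on a sulfonyl sulfur).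

Within the data shown here, two measured steps bear on this change. The exchange of a sulfonyl-linked aryl for a carbonyl-linked aryl on the ring nitrogen, a 1.8-fold higher number from compound 1 to compound 3 (0.24 log units; within the scatter) and a 1.4-fold higher number from compound 2 to compound 3 (0.14 log units; within the scatter), moved the number only within the scatter, and the closest analogue of a methyl taking the place of a chloro on an aromatic carbon, a 1.3-fold higher number from compound 1 to compound 2 (0.10 log units; within the scatter), also stayed within the scatter. Nothing among the three compounds suggests a move beyond the scatter for a second methyl on that ring. The expected step from compound 3 to compound 4 is therefore a 1.1-fold higher number from compound 3 to compound 4 (0.05 log units; within the scatter), no change beyond the scatter. The estimate for compound 4 in this assay is 2200 nM, with a likely range from 900 nM to 5500 nM.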

Compound 4, half-maximal inhibitory concentration: 2230 nM
The estimate for compound 4 lay 1.0-fold (0.01 log units) below the measured number; the measured number falls inside the stated range.
By their numbers in this assay, from the lowest: compounds 1, 2, 3 and 4 (each within the scatter of the next).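

Among these compounds, until this result, the sulfonyl sulfur had carried only 4-chlorophenyl, so the earlier steps spoke to this place only indirectly, through exchanges on the nitrogen and a methyl for chloro swap on a carbonyl-linked ring. In this assay, the direct exchange of 4-chlorophenyl for 3,4-dimethylphenyl gives a 1.1-fold higher number from compound 3 to compound 4 (0.06 log units; within the scatter), which lies within the scatter, so this assay does not separate a chlorine-bearing ring from one carrying two methyl groups at this place. No measurement is available to explain this result, and it stands here as an observation only.

Ordered by their numbers, the four compounds each lie within the scatter of the next, so no change shown here marks out a feature of the series that clearly matters for activity in this assay. From the compounds shown here alone, it remains open whether a group of a different kind on the ring attached to the sulfonyl sulfur, such as an amine or a carboxylic acid, or a longer chain in place of that ring, would shift the number beyond the scatter.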